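Phenyl to 5-methylthiophen-2-yl in an antiproliferative pair

The compounds below may be only part of what the source reports. "The series", "measured", "known", "first", "only" and "open" are said of these compounds alone.

Values measured in a functional assay on MCF7 cells (Homo sapiens) for antiproliferative activity, read by MTT assay, with a stated time of 48 h (a higher number here means a weaker inhibitor of growth, a lower number a stronger inhibitor of growth), are as follows
- compound 1 `CCOc1cc(NC(=O)CCCCCC(=O)Nc2cc(-c3ccccc3)ccc2N)cc2c1OCC([N+](=O)[O-])=C2` gives 7030 nM
- compound 2 `CCOc1cc(NC(=O)CCCCCCC(=O)Nc2cc(-c3ccccc3)ccc2N)cc2c1OCC([N+](=O)[O-])=C2` gives 9370 nM

Compound 2 (9370 nM) lies within the usual scatter of compound 1 (7030 nM), so this assay does not separate the two. For the measured compounds named here, compound 3 `CCOc1cc(NC(=O)CCCCCCC(=O)Nc2cc(-c3ccc(C)s3)ccc2N)cc2c1OCC([N+](=O)[O-])=C2` keeps the rest of compound 2 but carries 5-methylthiophen-2-yl in place of phenyl on an aromatic carbon, para to an amino group 5-methylthiophen-2-yl in place of phenyl on an aromatic carbon and this is the only change. Going by the values given here, compound 1 and compound 2 both carry phenyl there, so no measurement yet shows what such a swap does. The working expectation is therefore no shift beyond the scatter in either direction. The expected step (a 1.2-fold lower number from compound 2 to compound 3 (0.10 log units; within the scatter)) is an estimate with wide uncertainty. Compound 3 is estimated at 7500 nM (expected range 3000 nM to 18000 nM).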

Compound 3, concentration for 50% growth inhibition: 5330 nM
For compound 3 the middle estimate is 1.4-fold (0.15 log units) above the measured one; the range from low to high includes it.
By their numbers in this assay, from the lowest: compounds 3, 1 and 2 (each within the scatter of the next).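

In this assay, for the compounds shown here, placing 5-methylthiophen-2-yl instead of phenyl on the aromatic carbon para to an amino group gives a 1.8-fold lower number from compound 2 to compound 3 (0.25 log units; within the scatter) and so gives the first reading of what a change at this position does. At the chain length of compound 2, a five-membered aromatic ring with one hetero atom and a methyl group can therefore stand in place of the six-membered carbon ring with no shift beyond the scatter. No measurement bears on why the two compounds read as they do.

The compounds shown leave open whether the same swap would also stay within the scatter on the shorter chain of compound 1. They also leave open how an unsubstituted thiophen-2-yl or a pyridin-3-yl would read at this position.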